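The source may report more compounds than this note shows. Statements on the series, on what has been measured and on what is new or still open speak of the compounds shown alone.

Measured in an ADME assay on microsomes from liver (Rattus norvegicus) for metabolic stability; on this read-out higher numbers stand for a longer-lived compound and lower numbers for a shorter-lived compound:
- compound 1 `CC(C)C(/C=C1\SC(=O)NC1=O)c1ccc(-c2ccc3cccc(F)c3c2)[nH]c1=O`: 2.62 h
- compound 2 `CC(C)C(CC1NC(=O)NC1=O)c1ccc(-c2ccc3cccc(F)c3c2)[nH]c1=O`: 0.35 h
- compound 3 `CC(C)C(c1ccc(-c2ccc3cccc(F)c3c2)[nH]c1=O)C1C(=O)NC(=O)N1C`: 0.263 h

Compound 3 and compound 2 cannot be told apart on these numbers, with a 1.3-fold lower number from compound 2 to compound 3 (0.12 log units; within the scatter). Both stand well under compound 1, as shown by a 7.5-fold lower number from compound 1 to compound 2 (0.87 log units; beyond the scatter) and by a 10-fold lower number from compound 1 to compound 3 (1.00 log units; beyond the scatter).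

Compound 4 `CC(C)C(/C=C1/C(=O)NC(=O)N1C)c1ccc(-c2ccc3cccc(F)c3c2)[nH]c1=O` differs from compound 3 by a group of 9 heavy atoms (5 carbon, 2 nitrogen, 2 oxygen; one five-membered non-aromatic ring with 2 hetero atoms) in place of a group of 8 heavy atoms (4 carbon, 2 nitrogen, 2 oxygen; one five-membered non-aromatic ring with 2 hetero atoms), on a saturated chain carbon bound to an aromatic carbon and a saturated chain carbon. Compound 4 shares with compound 1 a ring joined to the chain through a double bond, which compound 2 and compound 3 lack. Going by the values given here, no measured step isolates this change. The nearest guide is a 10-fold lower number from compound 1 to compound 3 (1.00 log units; beyond the scatter), but that step also exchanges one ring for another, so only part of it can be expected to carry over. The swap seen in a 1.3-fold lower number from compound 2 to compound 3 (0.12 log units; within the scatter) suggests that moving the ring's attachment alone does little. A moderate rise is therefore expected, with the estimate being a 2.7-fold higher number from compound 3 to compound 4 (0.43 log units; beyond the scatter). For compound 4 the estimated value is 0.7 h, with an expected range of 0.25 h to 2.2 h.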

Compound 4, half-life: 1.08 h
Compound 4: middle estimate off by 1.5-fold (0.19 log units), on the low side, within the range that was stated.
By their numbers in this assay, from the lowest: compounds 3 and 2 (each within the scatter of the next); then compound 4; then compound 1.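

In this assay the group with the ring joined to the chain through a double bond gives a 4.1-fold higher number from compound 3 to compound 4 (0.61 log units; beyond the scatter) and a 3.1-fold higher number from compound 2 to compound 4 (0.49 log units; beyond the scatter), so at this saturated chain carbon that link goes with the higher numbers even without sulfur in the ring, and none of the four compounds goes against this. Both compounds with that link still differ, with a 2.4-fold lower number from compound 1 to compound 4 (0.38 log units; beyond the scatter), so the link alone does not cover the whole gap to the sulfur-containing ring. Nothing available explains either change.

The compounds shown leave open whether the methyl on the ring nitrogen of compound 4 contributes to its number. They also leave open whether the ring is needed at all, as a carboxylic acid or an open-chain amide at this place would show.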